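Sesquiterpene lactone esters: a pyridyl variant of compound 1

The source may hold more compounds than are shown below. What is called first, only, known or untested is meant among the compounds shown, and "the series" means these compounds.

Compound 1 `C=C1C(=O)O[C@H]2CC3=C[C@H](C/C(C)=C/[C@@H](OC(=O)/C=C/c4cccc(OC)c4)[C@H]12)OC3=O` carries a 2-(3-methoxyphenyl)ethenyl group on the ester carbonyl. In a functional assay on NCI-H460 cells (Homo sapiens) for cytotoxicity, read by MTT assay, with a stated time of 48 h (a higher number here means a weaker inhibitor, a lower number a stronger inhibitor), compound 1 gives only a limit, > 10000 nM, and no number. Two esters share the core with a saturated group in place of that ethenyl chain: compound 2 `C=C1C(=O)O[C@H]2CC3=C[C@H](C/C(C)=C/[C@@H](OC(=O)CC4CCCCC4)[C@H]12)OC3=O` gives 2000 nM in this assay, and compound 3 `C=C1C(=O)O[C@H]2CC3=C[C@H](C/C(C)=C/[C@@H](OC(=O)C4CC4)[C@H]12)OC3=O` gives 3000 nM. The step from the limit is an at least 5.0-fold lower number from compound 1 to compound 2 (0.69 log units; beyond the scatter) and an at least 3.3-fold lower number from compound 1 to compound 3 (0.52 log units; beyond the scatter); between the two saturated esters it is a 1.5-fold higher number from compound 2 to compound 3 (0.18 log units; within the scatter). Compound 1 thus stands at the weak end of the three, at the limit (the limit of > 10000 nM in this assay, at which 1 of the 3 values shown sits).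

Compound 4 `C=C1C(=O)O[C@H]2CC3=C[C@H](C/C(C)=C/[C@@H](OC(=O)/C=C/c4ccncc4)[C@H]12)OC3=O` keeps the ethenyl chain and its ester and changes only the aromatic ring: pyridin-4-yl in place of 3-methoxyphenyl on a double-bonded chain carbon bound to a double-bonded chain carbon. Going by the values given here, no measured step touches the ring alone; the two steps that leave compound 1 both remove the whole ethenyl chain, so they speak only to the chain, not to a pyridin-4-yl for 3-methoxyphenyl swap. With the conjugated ester retained, compound 4 is expected to sit close to compound 1, so the estimated step is a number no higher from compound 1 to compound 4 (the limit leaves the size open), no firm direction beyond the scatter. Compound 4 is therefore estimated at 10000 nM in this assay, with a range from 3000 nM to 30000 nM, and a real chance that only a limit is reported.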

Compound 4, half-maximal inhibitory concentration: 2100 nM
Estimate against measurement, compound 4: 4.8-fold (0.68 log units) above, and the stated range ends above it.
By their numbers in this assay, from the lowest: compounds 2, 4 and 3 (each within the scatter of the next). At a limit, above all of these: compound 1.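

At this place, on a double-bonded chain carbon bound to a double-bonded chain carbon, changing the aromatic ring alone is enough to move the ethenyl ester in this assay: pyridin-4-yl in place of 3-methoxyphenyl gives an at least 4.7-fold lower number from compound 1 to compound 4 (0.67 log units; beyond the scatter). The earlier steps shown here all removed the whole chain, whereas compound 4 keeps it and shows that an ethenyl ester can read level with the saturated esters, with a 1.4-fold lower number from compound 3 to compound 4 (0.15 log units; within the scatter) and a 1.1-fold higher number from compound 2 to compound 4 (0.02 log units; within the scatter). Compound 1 remains a limit and not a number, so only a lower bound exists for the size of the ring step: the limit of > 10000 nM in this assay, at which 1 of the 4 values shown sits.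

The compounds shown do not separate the entry of the ring nitrogen from the departure of the methoxy group, a question that a plain phenyl or a pyridin-3-yl on the same chain would address. They also leave open how an amine on the ring, as in 4-(dimethylamino)phenyl, or a longer chain between the ring and the ester carbonyl would read in this assay.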